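The compounds below may be only part of what the source reports. "The series", "measured", "known", "first", "only" and "open" are said of these compounds alone.

Measured in an ADME assay on MOLT-3 cells (Homo sapiens) for cytotoxicity, with a stated time of 7 days; on this read-out lower numbers stand for higher toxicity in this test and higher numbers for lower toxicity in this test:
- compound 1 `CCCCCCCCOc1nc(N)nc2c1ncn2/C=C1/CC1(CO)CO`: > 20000 nM (a limit)
- compound 2 `CCCCCCOc1nc(N)nc2c1ncn2/C=C1/CC1(CO)CO`: > 20000 nM (a limit)

Compound 2 has no number, only the limit > 20000 nM.

Next comes compound 3 `CCCCNc1nc(N)nc2c1ncn2/C=C1/CC1(CO)CO`, with butylamino in place of hexyloxy on an aromatic carbon.

Among the measured compounds shown here, the one measured step, a step that the two limits leave unreadable from compound 1 to compound 2, concerns chain length and gives no size to carry over. For the measured compounds named here, the series so far shows only (the limit of > 20000 nM in this assay, at which 2 of the 2 values shown sit). No readable step or direction can therefore be expected in this assay.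

The estimated change is a step that the limit leaves unreadable from compound 2 to compound 3, with the result likely to be reported only as a limit.

For compound 3 the estimate is 25000 nM, with an expected range of 8000 nM to 60000 nM.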

Compound 3, half-maximal cytotoxic concentration: > 20000 nM
Compound 3: only a limit was reported; the forecaster's own chance of this, stated with the estimate: 70%; the middle value does not contradict the limit.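

No step can be read among compound 1, compound 2 and compound 3 in this assay, as each is reported only as a limit: the limit of > 20000 nM in this assay, at which 3 of the 3 values shown sit.

The compounds shown leave open whether octyloxy, hexyloxy and butylamino differ at all on this read-out.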